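From cyclopentyl back to an aromatic ring

The source may report more compounds than this note shows. Statements on the series, on what has been measured and on what is new or still open speak of the compounds shown alone.

Compound 3 `O=C(Nc1cccc(CNc2nccnc2Cl)c1)NC1CCCC1` gives in a functional assay on T-24 cells (Homo sapiens) for antiproliferative activity, read by MTT assay, with a stated time of 48 h (on this read-out lower numbers stand for stronger inhibition and higher numbers for weaker inhibition), only a limit, > 40000 nM, which marks the edge of what the assay reports the limit of > 40000 nM in this assay, at which 1 of the 3 values shown sits, rather than a number. Its two measured relatives carry aromatic groups at the same place: compound 1 `Cc1ccc(NC(=O)Nc2cccc(CNc3nccnc3Cl)c2)cc1` gives 9820 nM and compound 2 `O=C(Nc1cccc(CNc2nccnc2Cl)c1)Nc1ccc(Cl)cc1Br` gives 6650 nM. Compound 4 `COc1ccccc1NC(=O)Nc1cccc(CNc2nccnc2Cl)c1` differs from compound 3 by 2-methoxyphenyl in place of cyclopentyl on an amide-type nitrogen. For the measured compounds named here, the steps that bear on this change are an at least 4.0-fold higher number from compound 1 to compound 3 (0.60 log units; beyond the scatter) and an at least 6.0-fold higher number from compound 2 to compound 3 (0.77 log units; beyond the scatter), both beyond the scatter, so returning to an aromatic ring should lower the number by a modest step; between the two aromatic compounds the difference was a 1.5-fold lower number from compound 1 to compound 2 (0.17 log units; within the scatter). Compound 4 is therefore expected to sit near 8000 nM, between 3000 nM and 30000 nM, an expected step of an at least 5.0-fold lower number from compound 3 to compound 4 (0.69 log units; beyond the scatter).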

Compound 4, half-maximal inhibitory concentration: 10400 nM
Compound 4: the middle estimate sits 1.3-fold (0.11 log units) below what was measured, within the range that was stated.
By their numbers in this assay, from the lowest: compounds 2, 1 and 4 (each within the scatter of the next). At a limit, above all of these: compound 3.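

The move from cyclopentyl to 2-methoxyphenyl brings an at least 3.8-fold lower number from compound 3 to compound 4 (0.58 log units; beyond the scatter) and shows that an aromatic ring carrying an oxygen also stands apart from cyclopentyl. Among the aromatic groups, the comparisons give a 1.6-fold higher number from compound 2 to compound 4 (0.19 log units; within the scatter) and a 1.1-fold higher number from compound 1 to compound 4 (0.02 log units; within the scatter) so these three groups cannot be told apart here. The first step has no exact size, since compound 3 gives only a limit: the limit of > 40000 nM in this assay, at which 1 of the 4 values shown sits.

For the compounds shown here, the contrast rests on cyclopentyl as the only non-aromatic group. Going by these compounds, how an amine or a carboxylic acid on the aromatic ring, or a longer chain in its place, would behave stays open.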